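The compounds below may be only part of what the source reports. "The series", "measured", "known", "first", "only" and "open" are said of these compounds alone.

Compound 1 `COc1cc(-n2ncnc2-c2ccc(C)cc2)cc(OC)c1OC` gives 90 nM
Compound 2 `COc1cc(-c2ncnn2-c2ccc(F)cc2)cc(OC)c1OC` gives > 10000 nM (a limit)

Going by the values given here, in a functional assay on HL-60 cells (Homo sapiens) for antiproliferative activity, read by MTT assay, with a stated time of 72 h (a lower number here means a stronger inhibitor, a higher number a weaker inhibitor), compound 1 gives 90 nM as the only true number so far. Compound 2 reads > 10000 nM as a limit of the assay and not a number.

Compound 3 `COc1cc(-n2ncnc2-c2ccc(OC(F)(F)F)cc2)cc(OC)c1OC` carries trifluoromethoxy in place of methyl on an aromatic carbon, para to a large group (trifluoromethoxy in place of methyl on an aromatic carbon). Among the compounds with values here, no measured step shows what this swap does. The expected change in this assay is a moderate loss of strength, estimated as a 3.3-fold higher number from compound 1 to compound 3 (0.52 log units; beyond the scatter) with wide uncertainty. Compound 3 is expected to give about 300 nM within an estimated range of 60 nM to 3000 nM for now.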

Compound 3, half-maximal inhibitory concentration: > 10000 nM
Compound 3 ended at the assay's limit (the forecaster's own chance of this, stated with the estimate: 10%); middle value at least 33-fold (1.52 log units) away from the limit.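

At this position, para to a large group, the ring does not accept every group: trifluoromethoxy in place of methyl gives an at least 110-fold higher number from compound 1 to compound 3 (2.04 log units; beyond the scatter). Compound 3 reads > 10000 nM, which is a limit of the assay and not a number. The step is therefore only a bound, and its true size stays unknown: the limit of > 10000 nM in this assay, at which 2 of the 3 values shown sit.

A single swap cannot tell which feature of trifluoromethoxy accounts for the loss. The compounds shown also leave open whether a chlorine atom or an amine at this place would keep the strength of compound 1, 90 nM.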